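This account rests on a few compounds, and the source may have more. Where it says the series, first, only, none or still open, it means among the compounds named here.

Among the measured compounds shown here, compound 2 `O=C(CCCCCCN(Cc1ccc(F)cc1)c1ncc(C(=O)NCCCn2ccnc2)s1)NO` stands lowest of the two numbers so far in a functional assay on HCT-116 cells (Homo sapiens) for inhibition, read by MTT assay, with a stated time of 72 h; a lower number here means a stronger inhibitor, a higher number a weaker inhibitor: compound 2 gives 9700 nM, while compound 1 `O=C(/C=C/c1ccc(CN(Cc2ccc(F)cc2)c2ncc(C(=O)NCCCn3ccnc3)s2)cc1)NO` gives 83000 nM, and the step of an 8.6-fold lower number from compound 1 to compound 2 (0.93 log units; beyond the scatter) separates them by more than the scatter. Compound 3 `O=C(NO)c1ccc(CN(Cc2ccc(F)cc2)c2ncc(C(=O)NCCCn3ccnc3)s2)cc1` has not yet been measured. It differs from compound 2 by the change (4-(hydroxycarbamoyl)phenyl in place of 5-(hydroxycarbamoyl)pentyl on a saturated chain carbon bound to a nitrogen on an aromatic ring). For the measured compounds named here, the only step that bears on this is the one from compound 1 to compound 2, where an aromatic carrier of the hydroxycarbamoyl group gave way to a saturated chain and the number fell. Compound 3 returns to an aromatic carrier, now a 4-(hydroxycarbamoyl)phenyl rather than the 4-(2-(hydroxycarbamoyl)ethenyl)phenyl of compound 1, so a higher number than compound 2 is expected in this assay, of modest size, a 4.1-fold higher number from compound 2 to compound 3 (0.62 log units; beyond the scatter). Compound 3 is therefore estimated at 40000 nM, within a range from 10000 nM to 150000 nM.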

Compound 3, half-maximal inhibitory concentration: 99000 nM
Compound 3: the middle estimate sits 2.5-fold (0.39 log units) below what was measured, within the range that was stated.
By their numbers in this assay, from the lowest: compound 2; then compounds 1 and 3 (each within the scatter of the next).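

In this assay, among the compounds shown here, 4-(hydroxycarbamoyl)phenyl in place of 5-(hydroxycarbamoyl)pentyl gives a 10-fold higher number from compound 2 to compound 3 (1.01 log units; beyond the scatter), so the lower number of the saturated chain now holds against a second aromatic carrier and not only against the one in compound 1. Hydroxycarbamoyl in place of 2-(hydroxycarbamoyl)ethenyl on an aromatic carbon gives a 1.2-fold higher number from compound 1 to compound 3 (0.08 log units; within the scatter), so the ethenyl link makes no difference that can be read in this assay. Nothing available gives a reason for the gap between the chain and the aromatic carriers.

Still open, as far as these compounds go, is whether a longer or a shorter saturated chain would move the number further from that of the pentyl chain. Also open, from the compounds shown here alone, is whether a cyclohexyl carrier would read like the chain or like the phenyl, and what a carboxylic acid in place of the hydroxycarbamoyl group would give.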